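The source may report more compounds than this note shows. Statements on the series, on what has been measured and on what is new or still open speak of the compounds shown alone.

Compounds measured in a functional assay on the whole organism with Rattus norvegicus as the target, at a dose of 3 mg/kg by the oral route; a higher number here means a stronger effect of the compound at the dose given, a lower number a weaker effect:
compound 1, `O=C(Nc1nn[nH]n1)c1cc(Cl)cc(-c2ccc(Cl)cc2)n1`, 11%;
compound 2, `COc1ccc(-c2cccc(C(=O)Nc3nn[nH]n3)n2)cc1`, 36%;
compound 3, `Nc1ccc(-c2cccc(C(=O)Nc3nn[nH]n3)n2)cc1`, 81%.

Compound 3 stands highest of the three numbers, with compound 2 nearest and compound 1 furthest. Within the data shown here, the one single-point step known is a number 45 percentage points higher from compound 2 to compound 3 (beyond the scatter), which concerns the amino group and not the core ring. Compound 4, `Cc1cc(C(=O)Nc2nn[nH]n2)nc(-c2ccc(N)cc2)c1`, differs from compound 3 by methyl in place of hydrogen on an aromatic carbon. Among the measured compounds shown here, no measured step changes that position alone; compound 1 carries a chloro there but also a second chloro, so its two values with compound 3 cannot be separated. A step of a number 6 percentage points lower from compound 3 to compound 4 (within the scatter) is therefore expected, within the scatter. Compound 4 is estimated at 75%, between 50% and 95%.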

Compound 4, a percentage reported as inhibition, in the whole organism at one dose (the size of the read-out at that dose, not a potency): 100%
Compound 4: middle estimate off by 25 percentage points, on the low side, and the stated range ends below it.
By their numbers in this assay, from the lowest: compound 1; then compound 2; then compound 3; then compound 4.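

In this assay, among these compounds, methyl in place of hydrogen on the aromatic carbon opposite the ring nitrogen gives a number 19 percentage points higher from compound 3 to compound 4 (beyond the scatter) and so provides the only clean reading of this position. It shows that this position tolerates a small added group and that the read-out can rise with the 4-aminophenyl group in place. Nothing available accounts for the gain.

On these data alone, whether ethyl or methoxy at this position would do the same remains open. So does whether methyl would give a similar step in compound 2, which carries methoxy instead of the amino group.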